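Swapping the methylindolyl for a methoxyphenyl

The source may hold more compounds than are shown below. What is called first, only, known or untested is meant among the compounds shown, and "the series" means these compounds.

For the measured compounds named here, compound 3 `COc1cc(-c2ccnc3cc(-c4ccc5ccn(C)c5c4)nn23)cc(OC)c1OC` gives 829 nM in a functional assay on A549 cells (Homo sapiens) for inhibition, read by CCK-8 assay, with a stated time of 48 h (on this read-out higher numbers stand for weaker inhibition and lower numbers for stronger inhibition), and stands second highest of the three numbers so far. Compound 1 `COc1cc(-c2ccnc3cc(-c4ccc(Cl)cc4)nn23)cc(OC)c1OC` gives 3070 nM and compound 2 `COc1cc(-c2ccnc3cc(-c4c[nH]c5ccccc45)nn23)cc(OC)c1OC` gives 29 nM; the connecting steps are a 3.7-fold lower number from compound 1 to compound 3 (0.57 log units; beyond the scatter) and a 29-fold higher number from compound 2 to compound 3 (1.46 log units; beyond the scatter). Compound 4 `COc1ccc(-c2cc3nccc(-c4cc(OC)c(OC)c(OC)c4)n3n2)cc1` differs from compound 3 by 4-methoxyphenyl in place of 1-methyl-1H-indol-6-yl on an aromatic carbon. Going by the values given here, no measured step replaces the fused group with a plain substituted phenyl, but compound 1 carries such a phenyl on the same aromatic carbon, and the step of a 3.7-fold lower number from compound 1 to compound 3 (0.57 log units; beyond the scatter) shows that the fused group gave the lower number. Compound 4 is therefore expected to shift toward weaker inhibition by a 3.0-fold higher number from compound 3 to compound 4 (0.48 log units; beyond the scatter), landing near the number for compound 1. The estimate for compound 4 is 2500 nM, within 800 nM to 8000 nM.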

Compound 4, half-maximal inhibitory concentration: 376 nM
Compound 4: middle estimate off by 6.6-fold (0.82 log units), on the high side; the whole stated range lies above it.
By their numbers in this assay, from the lowest: compound 2; then compound 4; then compound 3; then compound 1.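

In this assay, the phenyl series at this aromatic carbon is not uniformly weak: 4-methoxyphenyl gives a lower number than 1-methyl-1H-indol-6-yl (a 2.2-fold lower number from compound 3 to compound 4 (0.34 log units; beyond the scatter)), reversing the order suggested by the 4-chlorophenyl comparison. The substituent on the phenyl therefore matters, as methoxy in place of chloro shows (an 8.2-fold lower number from compound 1 to compound 4 (0.91 log units; beyond the scatter)), yet 4-methoxyphenyl still trails 1H-indol-3-yl (a 13-fold higher number from compound 2 to compound 4 (1.11 log units; beyond the scatter)). Nothing available explains these shifts.

Open, as far as these compounds go, is whether an amine or a longer ethoxy chain on the phenyl would lower the number further. The compounds also leave open what 1-methyl-1H-indol-3-yl would give, which would separate the effect of the methyl from that of the attachment point.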